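The source may report more compounds than this note shows. Statements on the series, on what has been measured and on what is new or still open speak of the compounds shown alone.

Compound 1 `Cc1cccc(NC(=O)Nc2ccc(-c3cccc4c3CNC4=O)cc2Cl)c1`: 99 nM
Compound 2 `Cc1cccc(NC(=O)Nc2ccc(-c3ccc(NC(=O)c4cccnc4)c4c3CNC4=O)cc2)c1`: 11 nM

In a functional assay on NIH3T3 cells (Mus musculus) for inhibition (on this read-out higher numbers stand for weaker inhibition and lower numbers for stronger inhibition), compound 2 has the lower of the two numbers at 11 nM, and its gap to compound 1 lies beyond the scatter. These two compounds differ in more than one place, so their gap cannot be tied to any single group.

Compound 3 `COc1ccc(-c2ccc(NC(=O)Nc3cccc(C)c3)cc2)c2c1C(=O)NC2` keeps the rest of compound 2 but changes one group: methoxy in place of ((pyridin-3-yl)carbonyl)amino on an aromatic carbon. Going by the values given here, no measured pair shows this change on its own. Compound 1 carries neither group and gives 99 nM, so it offers only a rough guide. A moderate loss of inhibition is therefore expected, an estimated 3.6-fold higher number from compound 2 to compound 3 (0.56 log units; beyond the scatter). The expected value for compound 3 is 40 nM, with an estimated range of 12 nM to 150 nM.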

Compound 3, half-maximal inhibitory concentration: 170 nM
Compound 3: the middle estimate sits 4.3-fold (0.63 log units) below what was measured; the measured number lies above the stated range.
By their numbers in this assay, from the lowest: compound 2; then compounds 1 and 3 (each within the scatter of the next).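

In this assay, putting methoxy in place of ((pyridin-3-yl)carbonyl)amino gives a 15-fold higher number from compound 2 to compound 3 (1.19 log units; beyond the scatter), so this single aromatic carbon, para to a large group, has a strong bearing on inhibition. The group that leaves is much the bigger of the two, with 9 heavy atoms against 2, and it brings a six-membered aromatic ring and 1 hydrogen-bond donor that methoxy lacks. Nothing available explains the size of this step or singles out one of these differences as the one that matters.

Still open, from the compounds shown here alone, is which part of the larger group counts: an acetylamino group would keep the amide without the ring, and a plain amine would keep only the nitrogen. Going by these compounds, compound 1 has neither group but also differs elsewhere, so how methoxy compares with a bare hydrogen here remains unknown.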